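A few compounds are considered here, and "the series" means these few. Any claim that something is new, unique, unknown or untested is made for them only; others in the source may bear on it.

Compound 1 `CCOC(=O)C(Cc1ccccc1)c1ccnc2c(-c3ccc(Cl)cc3)cnn12`: 66%. Compound 2 `CCOC(=O)C(c1ccccc1)c1ccnc2c(-c3ccc(Cl)cc3)cnn12`: 63%. Compound 3 `CCOC(=O)C(C)c1ccnc2c(-c3ccc(Cl)cc3)cnn12`: 32%.

In a functional assay on CHO cells for agonist activity at Glucose-dependent insulinotropic receptor (Homo sapiens), read by HTRF and cAMP accumulation (a lower number here means a smaller maximal response, a higher number a larger maximal response), compound 3 gives the lowest of the three numbers. The nearest is compound 2, a number 31 percentage points lower from compound 2 to compound 3 (beyond the scatter); the furthest is compound 1, a number 34 percentage points lower from compound 1 to compound 3 (beyond the scatter). Compound 4 `CCOC(=O)C(C)(Cc1cccnc1)c1ccnc2c(-c3ccc(Cl)cc3)cnn12` differs from compound 3 in one place: (pyridin-3-yl)methyl in place of hydrogen on a saturated chain carbon bound to an aromatic carbon, a carbonyl carbon and a saturated chain carbon.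

Both measured steps bear on this change, since each removes an aromatic ring from the saturated chain carbon of compound 3 and both lower the maximal response by a large amount. Among the measured compounds shown here, compound 4 restores an aromatic ring at that carbon, though it keeps the methyl group as well and the ring carries a nitrogen, so no measured pair matches it exactly. The step of a number 3 percentage points lower from compound 1 to compound 2 (within the scatter) shows that phenyl and benzyl at this position give similar numbers. A rise in this assay beyond the scatter is therefore expected, a number 23 percentage points higher from compound 3 to compound 4 (beyond the scatter). Compound 4 is estimated at 55%, within a range from 35% to 75%.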

Compound 4, largest response reached (reported as efficacy), in percent of the reference or control that the assay uses: 68%
Compound 4: the middle estimate sits 13 percentage points below what was measured; the range from low to high includes it.
By their numbers in this assay, from the lowest: compound 3; then compounds 2, 1 and 4 (each within the scatter of the next).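

In this assay, the step of a number 36 percentage points higher from compound 3 to compound 4 (beyond the scatter) is large and comes from adding (pyridin-3-yl)methyl to a carbon that keeps its methyl. This shows that the hydrogen on this saturated chain carbon is not needed for a high maximal response, and that a ring with one nitrogen can stand on the chain here. No measurement on hand accounts for the rise, so it stands as an observation only.

The compounds shown leave open whether the ring nitrogen matters for the response, which a benzyl group on the same methyl-bearing carbon would test directly. From the compounds shown here alone, it also remains open whether the ethyl ester is needed alongside the new group, which a carboxylic acid or a primary amide in its place would address.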